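Swapping One Alkyl Chain for Another on a Shared Core

The source may report more compounds than this note shows. Statements on the series, on what has been measured and on what is new or still open speak of the compounds shown alone.

Compound 1 `C/N=C(\NC#N)Nc1cccnc1`, compound 2 `Cc1cc(C)c(/N=C(\NC#N)NC(C)(C)C)c(C)n1` and compound 3 `CC(C)(C)C/N=C(\NC#N)Nc1ccncc1` share a common core and have been tested in a functional assay on the whole organism (blood, strain Wistar-Okamoto) with Rattus norvegicus as the target, with a stated time of 5 days; on this read-out lower numbers stand for an effect already at smaller amounts and higher numbers for an effect only at larger amounts of compound. For compound 1 the result is a limit of the assay and not a number, > 50 mg/kg. For compound 2 the result is likewise a limit of the assay, > 50 mg/kg. Compound 3 is the only one of the three with a true number, 5 mg/kg, and it therefore stands apart from the limit of > 50 mg/kg in this assay, at which 2 of the 3 values shown sit.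

Compound 4 `CCC(C)C(C)/N=C(\NC#N)Nc1ccncc1` has not yet been measured. It differs from compound 3 in one place: 1,2-dimethylbutyl in place of neopentyl on a double-bonded nitrogen. Both groups are alkyl chains with no ring, no hydrogen-bond donors and no hydrogen-bond acceptors, so the expected step is no change at the digits printed from compound 3 to compound 4 (within the scatter), that is, none beyond the usual scatter and with no clear direction. For compound 4 the expected value in this assay is 5 mg/kg, with a likely range from 2 mg/kg to 15 mg/kg.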

Compound 4, minimum effective dose: 8 mg/kg
Compound 4: middle estimate off by 1.6-fold (0.20 log units), on the low side; low and high end bracket the measured number.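

In this assay, replacing neopentyl with 1,2-dimethylbutyl gives a 1.6-fold higher number from compound 3 to compound 4 (0.20 log units; within the scatter), so the two chains cannot be told apart at this place on a double-bonded nitrogen. This is the first pair shown that differs in one place only, which makes it the first direct reading of this position: a second alkyl chain can stand there with no change beyond the scatter. Compound 4 gives a true number, whereas compound 1 and compound 2 stay at a limit of the assay and not at a number: the limit of > 50 mg/kg in this assay, at which 2 of the 4 values shown sit.

The compounds shown leave open what a longer chain such as octyl, or a cyclohexyl ring, would do at this place. They also leave open whether an amine or a carboxylic acid on the chain would keep the effect seen with compound 3 and compound 4.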